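The source may report more compounds than this note shows. Statements on the series, on what has been measured and on what is new or still open speak of the compounds shown alone.

Measured so far in a functional assay on RXF 393 cells (Homo sapiens) for inhibition, read by sulforhodamine B assay, with a stated time of 48 h, tested at 10 uM; a lower number here means less inhibition, a higher number more inhibition at the concentration tested (going by the name of the read-out):
compound 1 `Fc1ccc(-c2cn3ccnc3c(-c3ccc4ncn(C5CCCCC5)c4c3)n2)cc1` gives 24.4%
compound 2 `Brc1ccc(-c2cn3ccnc3c(-c3ccc4ncn(C5CCCCC5)c4c3)n2)cc1` gives 34%

For the measured compounds named here, compound 2 carries the higher of these two numbers, but its only neighbour is compound 1, and the step of a number 9.6 percentage points higher from compound 1 to compound 2 (within the scatter) lies within the usual scatter, so the two compounds cannot be told apart on this evidence.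

Compound 3 `COc1ccccc1-c1cn2ccnc2c(-c2ccc3ncn(C4CCCCC4)c3c2)n1` has not yet been tested in this assay. It differs from compound 2 in one place: 2-methoxyphenyl in place of 4-bromophenyl on an aromatic carbon. Going by the values given here, the single step measured so far also exchanged a group on the 4-bromophenyl, bromo in place of fluoro, and that exchange gave a number 9.6 percentage points higher from compound 1 to compound 2 (within the scatter). Among the compounds with values here, nothing measured here shows what a 2-methoxyphenyl does, so the only guide is that one swap on this ring, which stayed inside the scatter.

On that basis compound 3 is expected to sit close to compound 2, with a step of about a number 6 percentage points lower from compound 2 to compound 3 (within the scatter). The estimate for compound 3 is therefore 28%, with a range from 8% to 50%.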

Compound 3, a percentage reported as inhibition, at one concentration (the size of the read-out at that concentration, not a potency): 0.95%
The estimate for compound 3 lay 27.1 percentage points above the measured number; the measured number lies below the stated range.
By their numbers in this assay, from the lowest: compound 3; then compounds 1 and 2 (each within the scatter of the next).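

In this assay, the group at this position of the shared core can clearly change the result: 2-methoxyphenyl in place of 4-bromophenyl gives a number 33.1 percentage points lower from compound 2 to compound 3 (beyond the scatter), and 2-methoxyphenyl in place of 4-fluorophenyl gives a number 23.5 percentage points lower from compound 1 to compound 3 (beyond the scatter). For the compounds shown here, the exchange of one halogen for another on the ring showed no such effect, so these are the first steps at this position that lie beyond the scatter. Nothing available here explains the drop.

Compound 3 changes both the kind of substituent on the phenyl ring and its place on that ring, so the two changes cannot be separated; a 4-methoxyphenyl would keep the methoxy group at the place the halogens occupy. From the compounds shown here alone, how a phenyl ring carrying an amine or a carboxylic acid would behave at this position also remains open.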